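This account rests on a few compounds, and the source may have more. Where it says the series, first, only, none or still open, it means among the compounds named here.

Measured compounds:
- compound 1, `Nc1ccc2cccc(OCC3CC4CCC3C4)c2n1`, 137 nM in an assay on cells with melanin-concentrating hormone receptor 1 (Homo sapiens) as the target, read by radioligand binding; a lower number here means a stronger inhibitor, a higher number a weaker inhibitor
- compound 2, `CCCOc1cccc2ccc(N)nc12`, 1100 nM in this assay
- compound 3, `CC(CC(C)(C)C)Oc1cccc2ccc(N3CCCCC3)nc12`; for compound 3 this assay gives only a limit, > 2000 nM

Compound 2 holds the highest of the two numbers recorded in this assay; compound 1 sits at the lower number, and the gap between the two lies beyond the scatter. Compound 3 contributes no number, only a limit, as the limit of > 2000 nM in this assay, at which 1 of the 3 values shown sits, states.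

Compound 4, `Nc1ccc2cccc(OCC3CCOC3)c2n1`, has not been measured. Against compound 2 the change is oxolan-3-yl in place of ethyl on a saturated chain carbon bound to an oxygen on an aromatic ring. For the measured compounds named here, no step between two measured compounds isolates this change, so the size of the step can only be inferred from the spread between compound 1 and compound 2, where a larger saturated group on the chain carbon bound to the oxygen accompanies the lower number.

For compound 4 in this assay a modest step downward from compound 2 is expected, a 1.8-fold lower number from compound 2 to compound 4 (0.26 log units; within the scatter), though it may not exceed the scatter. The estimate for compound 4 is 600 nM, with a range from 200 nM to 1800 nM.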

Compound 4, half-maximal inhibitory concentration: 115 nM
The estimate for compound 4 lay 5.2-fold (0.72 log units) above the measured number, outside the stated range (below it).
By their numbers in this assay, from the lowest: compounds 4 and 1 (each within the scatter of the next); then compound 2. At a limit, above all of these: compound 3.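

In this assay, for the compounds shown here, oxolan-3-yl in place of ethyl on a saturated chain carbon bound to an oxygen on an aromatic ring comes with a 9.6-fold lower number from compound 2 to compound 4 (0.98 log units; beyond the scatter), the first direct reading of a change at this position. Compound 1 gives 137 nM and compound 4 gives 115 nM, two values within the scatter of each other, so at this position a ring group carrying an oxygen and the all-carbon ring group of compound 1 cannot be told apart by their numbers. No measurement at hand bears on the reason for the step.

From the compounds shown here alone, whether the ring oxygen of oxolan-3-yl plays any part in the step remains open, since only a cyclopentyl group, its all-carbon counterpart, or a longer open chain such as butyl at the same place would separate the oxygen from the added size and the ring. Compound 3 gives only a limit, > 2000 nM, and it differs from the other compounds in more than one place, so it settles nothing about this position.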